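The source may report more compounds than this note shows. Statements on the series, on what has been measured and on what is new or still open speak of the compounds shown alone.

Measured so far in a functional assay on HCT-116 cells (Homo sapiens), read by fluorescence and BrdU incorporation, with a stated time of 48 h, tested at 10 uM; a lower number here means a stronger effect, a higher number a weaker effect of the compound at the concentration tested:
compound 1 `COc1cc(O)c(C(=O)/C=C/c2ccc(F)cc2)c(OC)c1` gives 59%
compound 2 `COc1cccc(/C=C/C(=O)c2c(OC)cc(OC)cc2OC)c1` gives 20%
compound 3 `COc1cc(OC)c(C(=O)/C=C/c2ccc(F)cc2)c(OC)c1` gives 23%

Compound 4 `COc1cccc(/C=C/C(=O)c2c(O)cc(OC)cc2OC)c1` is still to be measured. It differs from compound 2 by one change: hydrogen in place of methyl on an oxygen on an aromatic ring. The same change, at a place described in the same words, has already been made once in the series, from compound 3 to compound 1: hydrogen in place of methyl on an oxygen on an aromatic ring. That step was large, a number 36 percentage points higher from compound 3 to compound 1 (beyond the scatter). The two cores on which the change is made differ by 3-methoxyphenyl in place of 4-fluorophenyl on a double-bonded chain carbon bound to a double-bonded chain carbon; the values of the two parents lie within the scatter of each other, a number 3 percentage points higher from compound 2 to compound 3 (within the scatter). A step of about the same size is therefore expected here, a number 36 percentage points higher from compound 2 to compound 4 (beyond the scatter), resting on the earlier step of a number 36 percentage points higher from compound 3 to compound 1 (beyond the scatter). Compound 4 is estimated at 56% in this assay, with a range from 38% to 74%.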

Compound 4, a percentage reported as activity, at one concentration (the size of the read-out at that concentration, not a potency): 30%
For compound 4 the middle estimate is 26 percentage points above the measured one, outside the stated range (below it).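

Methoxy to hydroxy does not carry a fixed step size between these two cores in this assay: the same change on two cores in this assay, a number 36 percentage points higher (beyond the scatter) from compound 3 to compound 1 and a number 10 percentage points higher (within the scatter) from compound 2 to compound 4, 26 percentage points apart, beyond the scatter of two such steps.
On the core bearing 3-methoxyphenyl, the change gives a number 10 percentage points higher from compound 2 to compound 4 (within the scatter), so the earlier step is no reliable guide to its size on another core in this series.
Two pairs do not show what sets the gap, and neither 3-methoxyphenyl nor 4-fluorophenyl can be assigned as its cause.

The compounds shown leave open how the change behaves on further cores.
They also leave open whether an amine or a longer chain on the oxygen, such as ethoxy, in place of methoxy would follow either step.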